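The source may report more compounds than this note shows. Statements on the series, on what has been measured and on what is new or still open speak of the compounds shown alone.

Measured in a functional assay on NCI/ADR cells (Homo sapiens) for cytotoxicity, read by sulforhodamine B assay (on this read-out lower numbers stand for stronger inhibition of growth and higher numbers for weaker inhibition of growth), so far:

Compound 1 `CC1=CC[C@@H]([C@@](C)(O)CCCC(C)(C)NC(=S)N/N=C\c2ccc(C)cc2)CC1` gives 30500 nM
Compound 2 `COc1ccc(/C=N\NC(=S)NC(C)(C)CCC[C@](C)(O)[C@@H]2CC=C(C)CC2)cc1` gives 57000 nM
Compound 3 `CC1=CC[C@@H]([C@@](C)(O)CCCC(C)(C)NC(=S)N/N=C\c2ccc(N(C)C)cc2)CC1` gives > 100000 nM

The entry for compound 3 is a limit of the assay and not a number. Compound 1 has one close neighbour among the real numbers, and the gap is within the scatter (a 1.9-fold higher number from compound 1 to compound 2 (0.27 log units; within the scatter)). That step puts methoxy in place of methyl on the aromatic ring. Dimethylamino in place of methyl gives a larger step, beyond the scatter (an at least 3.2-fold higher number from compound 1 to compound 3 (0.51 log units; beyond the scatter)).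

The unmeasured compound 4 `CC1=CC[C@@H]([C@@](C)(O)CCCC(C)(C)NC(=S)N/N=C\c2cccc(Cl)c2)CC1` changes the aromatic group of compound 1 (3-chlorophenyl in place of 4-methylphenyl on a carbon with a double bond to nitrogen), with 3-chlorophenyl in place of 4-methylphenyl on a carbon with a double bond to nitrogen. Among the compounds with values here, no measured step brings in chlorine, so these two ring changes guide the forecast only loosely. On that basis, no step beyond the scatter is expected in this assay (a 1.0-fold lower number from compound 1 to compound 4 (0.01 log units; within the scatter)). For compound 4 the estimated value is 30000 nM (expected range 10000 nM to 90000 nM).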

Compound 4, concentration for total growth inhibition: 31900 nM
The estimate for compound 4 lay 1.1-fold (0.03 log units) below the measured number; the range from low to high includes it.
By their numbers in this assay, from the lowest: compounds 1, 4 and 2 (each within the scatter of the next). At a limit, above all of these: compound 3.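

In this assay, within the data shown here, 3-chlorophenyl in place of 4-methylphenyl on the carbon with a double bond to nitrogen gives no step that can be told from the scatter, at a 1.0-fold higher number from compound 1 to compound 4 (0.02 log units; within the scatter), so this position accepts a chlorine and a different ring pattern without a clear shift. The same holds against 4-methoxyphenyl, at a 1.8-fold lower number from compound 2 to compound 4 (0.25 log units; within the scatter), while 3-chlorophenyl separates from 4-(dimethylamino)phenyl, at an at least 3.1-fold lower number from compound 3 to compound 4 (0.49 log units; beyond the scatter). Compound 3 stands at a limit of the assay and not a number: the limit of > 100000 nM in this assay, at which 1 of the 4 values shown sits.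

The 3-chlorophenyl group differs from 4-methylphenyl both in its substituent and in where that substituent sits, and the compounds shown do not separate these two changes. On these data alone, how an unsubstituted phenyl, or a ring carrying a carboxylic acid, would read in this assay stays open.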